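A few compounds are considered here, and "the series" means these few. Any claim that something is new, unique, unknown or untested is made for them only; others in the source may bear on it.

Measured compounds:
compound 1, `CCOC(=O)c1nn(-c2ccccc2)c(-c2ccc(OC)cc2OC)c1-c1ccccc1`: 20.8%
compound 2, `CCOC(=O)c1nn(-c2ccccc2)c(-c2ccc(OC)cc2OC)c1C`: 5.81%
compound 3, `COc1ccc(C2=NN(C(=S)NC(=O)c3ccc(Cl)cc3)CC2c2ccccc2)c(OC)c1`: 1.43%

In a functional assay on the whole organism (strain albino) for inhibition, with Rattus norvegicus as the target, read by paw edema, with stated times of 30 min and 3 h, at a dose of 25 mg/kg by the intraperitoneal route (on this read-out lower numbers stand for less inhibition and higher numbers for more inhibition at the one dose given (going by the name of the read-out)), compound 1 gives the highest of the three numbers, and compound 3 gives the lowest. Among the measured compounds shown here, the one measured step between neighbours is a number 15 percentage points lower from compound 1 to compound 2 (beyond the scatter), a change at a different part of the shared core than the one considered now. Compound 4, `CCOC(=O)c1nn(-c2ccc(Cl)cc2)c(-c2ccc(OC)cc2OC)c1-c1ccccc1`, differs from compound 1 by chloro in place of hydrogen on an aromatic carbon. For the measured compounds named here, no measured step touches this position, so the only guidance is the value of compound 1 itself, and the change adds a single chlorine. Compound 4 is therefore expected to show a number 1.2 percentage points higher from compound 1 to compound 4 (within the scatter), within the scatter, with an estimated value of 22% and a range from 8% to 38%.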

Compound 4, a percentage reported as inhibition, in the whole organism at one dose (the size of the read-out at that dose, not a potency): 15%
Estimate against measurement, compound 4: 7 percentage points above; the measured number falls inside the stated range.
By their numbers in this assay, from the lowest: compounds 3, 2, 4 and 1 (each within the scatter of the next, the first and the last beyond it).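

Going from phenyl to 4-chlorophenyl in this assay gives a number 5.8 percentage points lower from compound 1 to compound 4 (within the scatter), so at this position a single chlorine brings no change that can be told from the usual scatter. Among the compounds shown here, this is the first reading at this ring, and it holds only for chloro on the core of compound 1. No further measurement bears on why the number stays within the scatter. The compounds shown leave open how an amine or a carboxylic acid at this same place would read, and whether it would move the number beyond the scatter.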